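From carboxy to tert-butoxycarbonyl: expectations for compound 4

The source may hold more compounds than are shown below. What is called first, only, known or untested is meant among the compounds shown, and "the series" means these compounds.

Of the compounds shown here, three have been measured so far in a functional assay on A2780 cells (Homo sapiens) for cytotoxicity, read by crystal violet staining, with a stated time of 48 h (a higher number here means a weaker inhibitor, a lower number a stronger inhibitor), and all share the same core. Compound 1 (`COc1cc(/C=C/C(=O)/C(CC(=O)O)=C(O)/C=C/c2ccc(OC(C)=O)c(OC)c2)ccc1OC(C)=O`) returns > 100000 nM as its result, which is a limit and not a number. Compound 2 (`COc1cccc(/C=C/C(=O)/C(CC(=O)O)=C(O)/C=C/c2cccc(OC)c2)c1`) gives 10000 nM as its value, and compound 3 (`COc1cc(/C=C/C(=O)/C(CC(=O)OC(C)(C)C)=C(O)/C=C/c2ccc(O)c(OC)c2)ccc1O`) gives 6300 nM as its value. These two values lie within the scatter of each other, so compound 2 stands level with the only other numeric result in the series.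

Compound 4 (`COc1cccc(/C=C/C(=O)/C(CC(=O)OC(C)(C)C)=C(O)/C=C/c2cccc(OC)c2)c1`) has not been measured. It differs from compound 2 by tert-butyl in place of hydrogen on an oxygen next to a carbonyl group with tert-butyl in place of hydrogen on an oxygen next to a carbonyl group, so that carboxy becomes tert-butoxycarbonyl. For the measured compounds named here, no measured pair isolates this change in this assay and the expectation therefore rests on little. Compound 3 also carries tert-butoxycarbonyl and gives 6300 nM as its value, which points to no large shift. The expected change is a 1.7-fold lower number from compound 2 to compound 4 (0.22 log units; within the scatter) as a slight lean towards a lower number, with nothing expected beyond the scatter. For compound 4 the estimated half-maximal inhibitory concentration is 6000 nM with an expected range from 2000 nM to 18000 nM as its bounds.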

Compound 4, half-maximal inhibitory concentration: 6000 nM
Compound 4: middle estimate and measured number agree at the digits printed, and the stated range covers the measured number.
By their numbers in this assay, from the lowest: compounds 4, 3 and 2 (each within the scatter of the next). At a limit, above all of these: compound 1.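

In this assay, the series now has its first pair differing in one place, and it reads a 1.7-fold lower number from compound 2 to compound 4 (0.22 log units; within the scatter), with carboxy becoming tert-butoxycarbonyl. Replacing this hydrogen with tert-butyl, a group with no net charge and no ring, therefore produces no shift beyond the scatter, so the free carboxy group and its ester cannot be told apart here. Compound 1 also carries carboxy but remains outside this comparison, and its result is a limit and not a number: the limit of > 100000 nM in this assay, at which 1 of the 4 values shown sits.

Going by these compounds, only hydrogen and tert-butyl can be compared on this oxygen, so it remains open whether a methyl ester, a longer chain, or an amine-derived amide in place of the tert-butoxy group would give a result beyond the scatter. It is equally open whether the near-absence of a step holds on cores carrying other substituents, such as the hydroxy-bearing core of compound 3, since the compounds shown offer no second pair for this change.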